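A Methyl Extension on a Cytotoxicity Series

The source may report more compounds than this note shows. Statements on the series, on what has been measured and on what is new or still open speak of the compounds shown alone.

The study concerns four compounds built on two cores. Compound 1 `CC1(c2cccc(Br)c2)ON=C(c2ccccc2Cl)O1` and compound 2 `CCC1(c2cccc(Br)c2)ON=C(c2ccccc2Cl)O1` share one core, while compound 3 `Cc1ccc(C2ON=C(c3ccc(Cl)cc3)O2)cc1` and compound 4 `CCc1ccc(C2ON=C(c3ccc(Cl)cc3)O2)cc1` share another. The difference between the two cores is not broken down here.

The three measured compounds were tested in an ADME assay on HEK293 cells (Homo sapiens) for cytotoxicity, read by MTT assay, with a stated time of 44 h; a higher number here means a weaker inhibitor, a lower number a stronger inhibitor. In this assay compound 1 gives > 100000 nM, which is a limit of the assay rather than a number. Compound 2 gives > 100000 nM, again a limit. Compound 3 gives > 100000 nM, also a limit. The change from compound 1 to compound 2 is methyl in place of hydrogen on a saturated chain carbon bound to a saturated ring carbon. The step it made, a step that the two limits leave unreadable from compound 1 to compound 2, cannot be read because both values sit at the limit of > 100000 nM in this assay, at which 3 of the 3 values shown sit.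

Compound 4 differs from compound 3 by methyl in place of hydrogen on a saturated chain carbon bound to an aromatic carbon. This is the same kind of change as that from compound 1 to compound 2, but the place differs: in compound 2 the methyl enters on a saturated chain carbon bound to a saturated ring carbon, whereas in compound 4 it enters on a saturated chain carbon bound to an aromatic carbon.

Because every measured value in this assay rests at the limit of > 100000 nM in this assay, at which 3 of the 3 values shown sit, the expected step is a step that the limit leaves unreadable from compound 3 to compound 4. Compound 4 is therefore estimated at 150000 nM, with a range from 60000 nM to 400000 nM, and the assay is expected most likely to report only a limit again.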

Compound 4, half-maximal inhibitory concentration: > 100000 nM
Compound 4 was reported as a limit; the forecaster's own chance of this, stated with the estimate: 85%; the middle value is on the limit's open side.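

In this assay compound 4 gives > 100000 nM, which is a limit of the assay and not a number. No new step can be read from compound 3 to compound 4, because both rest at the same limit: the limit of > 100000 nM in this assay, at which 4 of the 4 values shown sit.

The compounds shown leave open how strongly any of the four inhibits, and whether methyl in place of hydrogen changes that at either place.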